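Following one methyl-to-fluoro swap in solubility

The source may hold more compounds than are shown below. What is called first, only, known or untested is meant among the compounds shown, and "the series" means these compounds.

Values in a physicochemical assay for solubility, in phosphate buffer, with a stated time of 24 h, at pH 7.2; a lower number here means a less soluble compound, a higher number a more soluble compound:
- Compound 1 `Cc1cc(-c2ccc(C(=O)c3cc(F)cc(O)c3C)s2)cc(C)c1O`: 100000 nM
- Compound 2 `Cc1cc(-c2ccc(C(=O)c3cc(F)c(F)c(O)c3C)s2)cc(C)c1O`: 15000 nM
- Compound 3 `NS(=O)(=O)Oc1ccc(-c2ccc(C(=O)c3cc(F)c(F)c(O)c3F)s2)cc1`: > 200000 nM (a limit of the assay, not a number)

Among the two actual numbers, compound 2 at 15000 nM has the lower one. Compound 4 `Cc1cc(-c2ccc(C(=O)c3cc(F)c(F)c(O)c3F)s2)cc(C)c1O` keeps the rest of compound 2 but has fluoro in place of methyl on an aromatic carbon, ortho to a hydroxy group (fluoro in place of methyl on an aromatic carbon).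

Going by the values given here, only one measured step is a single change: a 6.7-fold lower number from compound 1 to compound 2 (0.82 log units; beyond the scatter). It swaps fluoro for hydrogen, not for methyl, so it is a guide to size and not a direct precedent. Compound 3 shares the entering fluoro with compound 4 but differs elsewhere too, and it offers only a limit, so it adds little.

A modest rise in this assay is therefore expected, though the direction is uncertain. The expected step is a 2.0-fold higher number from compound 2 to compound 4 (0.30 log units; within the scatter). For compound 4 the estimated solubility is 30000 nM, with an expected range from 8000 nM to 100000 nM.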

Compound 4, solubility: > 200000 nM
Compound 4 was reported as a limit; the forecaster's own chance of this, stated with the estimate: 5%; at least 6.6-fold (0.82 log units) between middle value and limit.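

In this assay, putting fluoro in place of methyl on the aromatic carbon ortho to a hydroxy group gives an at least 13-fold higher number from compound 2 to compound 4 (1.12 log units; beyond the scatter), the first change shown at this position and one that runs opposite to the earlier fluoro-for-hydrogen step. Compound 4 gives > 200000 nM, which is a limit of the assay and not a number. This step therefore gives only a minimum size, and more than one compound reaches the top of the measured range: the limit of > 200000 nM in this assay, at which 2 of the 4 values shown sit.

The compounds shown leave open whether the rise goes with fluoro itself or with the loss of methyl, as fluoro is the only replacement for methyl here. A chloro or methoxy group at this position, with the rest of compound 2 kept, would help separate the two.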